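A few compounds are considered here, and "the series" means these few. Any claim that something is new, unique, unknown or untested is made for them only; others in the source may bear on it.

Measured in a functional assay on A549 cells (Homo sapiens) for antiproliferative activity, read by MTT assay, with a stated time of 72 h; a lower number here means a stronger inhibitor, a higher number a weaker inhibitor:
- compound 1 `COc1cc(-n2cnc3ccc(-c4cccc(O)c4)cc32)cc(OC)c1OC`: 250 nM
- compound 2 `COc1cc(-n2cnc3ccc(-c4cccc(F)c4)cc32)cc(OC)c1OC`: 5270 nM
- compound 3 `COc1cc(-n2cnc3ccc(-c4ccc(O)cc4)cc32)cc(OC)c1OC`: 5090 nM

Compound 3 shares the high end of these numbers with compound 2, with nothing to separate them: a 1.0-fold lower number from compound 2 to compound 3 (0.02 log units; within the scatter). The gap to the remaining compound is large: a 20-fold higher number from compound 1 to compound 3 (1.31 log units; beyond the scatter).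

The next change gives compound 4 `COc1cccc(-c2ccc3ncn(-c4cc(OC)c(OC)c(OC)c4)c3c2)c1`, with 3-methoxyphenyl in place of 4-hydroxyphenyl on an aromatic carbon.

Among the measured compounds shown here, two measured steps bear on this change. The first is the gap above, which separates the 3-hydroxyphenyl and 4-hydroxyphenyl groups. The second is a 21-fold higher number from compound 1 to compound 2 (1.32 log units; beyond the scatter), which shows that a group numbered like the 3-hydroxyphenyl of compound 1 can still give a high number. The 3-methoxyphenyl group shares that numbering, so it may recover part of the gap, but compound 2 warns against expecting all of it. For the measured compounds named here, no methoxy compound has been measured yet, so the range stays wide.

A moderate move in this assay is expected, much smaller than the large steps above: a 2.5-fold lower number from compound 3 to compound 4 (0.41 log units; beyond the scatter). The estimate for compound 4 is 2000 nM, with an expected range of 400 nM to 8000 nM.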

Compound 4, half-maximal inhibitory concentration: 3180 nM
Beside the measured number, compound 4's estimate is 1.6-fold (0.20 log units) below it; measured number inside the range.
By their numbers in this assay, from the lowest: compound 1; then compounds 4, 3 and 2 (each within the scatter of the next).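

In this assay, methylating the hydroxy oxygen of compound 1 removes most of its lead, with a 13-fold higher number from compound 1 to compound 4 (1.10 log units; beyond the scatter) as the measured cost, so the 3-hydroxyphenyl substitution pattern is not enough when the oxygen is capped. Compound 4 is not separated from the other two high-number compounds, with a 1.6-fold lower number from compound 3 to compound 4 (0.20 log units; within the scatter) on one side and a 1.7-fold lower number from compound 2 to compound 4 (0.22 log units; within the scatter) on the other, so 3-methoxyphenyl, 3-fluorophenyl and 4-hydroxyphenyl cannot be ranked here. Among these four compounds, only the combination of a free hydroxy with the 3-substituted phenyl gives a low number, as moving the hydroxy in compound 3 or replacing it in compounds 2 and 4 each gives a number far from that of compound 1, and nothing shown accounts for this.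

Still open, as far as these compounds go, is whether any group other than hydroxy can hold the low number at this place, for example an amine in 3-aminophenyl or a carboxylic acid in 3-carboxyphenyl. A longer ether such as ethoxy would show nothing new if it stays with compound 4, but a hydroxymethyl group would test whether the oxygen must sit directly on the ring.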